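The source may report more compounds than this note shows. Statements on the series, on what has been measured and on what is new or still open speak of the compounds shown alone.

Measured compounds in a functional assay on A549 cells (Homo sapiens) for cytotoxicity, read by MTT assay, with a stated time of 24 h; a higher number here means a weaker inhibitor, a lower number a stronger inhibitor:

- Compound 1 `Fc1ccc(-n2cc(COc3ccccc3-c3nc4ccccc4s3)nn2)cc1Cl`: 16300 nM
- Compound 2 `c1ccc(-n2cc(COc3ccccc3-c3nc4ccccc4s3)nn2)cc1`: 16400 nM
- Compound 3 `Fc1ccccc1-c1cc(COc2ccccc2-c2nc3ccccc3s2)on1`: 22500 nM

All three share the same core, differing only in the aryl group on the five-membered ring. Compound 3 gives the largest of the three numbers in this assay, yet its gaps to compound 2 and to compound 1 both lie within the scatter, so the three compounds are not separable on these data.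

Compound 4 `Clc1ccc(-c2cc(COc3ccccc3-c3nc4ccccc4s3)on2)cc1` has not yet been measured. It differs from compound 3 in one place: 4-chlorophenyl in place of 2-fluorophenyl on an aromatic carbon.

Among the measured compounds shown here, only one measured step bears on an aryl swap of this kind. The step of a 1.0-fold higher number from compound 1 to compound 2 (0.00 log units; within the scatter) replaces a halogenated phenyl with an unsubstituted phenyl on an aromatic nitrogen and produces no change beyond the scatter. For the measured compounds named here, that step sits on a different ring of the core and swaps different halogens, so it is an indirect guide, but it is the only guide available. Going by the values given here, no measured pair shows a 4-chlorophenyl group at all.

On this basis the exchange of 2-fluorophenyl for 4-chlorophenyl in compound 4 is expected to give a step of a 1.1-fold lower number from compound 3 to compound 4 (0.03 log units; within the scatter) in this assay, that is, nothing beyond the scatter. Compound 4 is therefore estimated at 21000 nM, within a range of 9000 nM to 50000 nM.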

Compound 4, half-maximal inhibitory concentration: 18800 nM
Estimate against measurement, compound 4: 1.1-fold (0.05 log units) above, and the stated range covers the measured number.
By their numbers in this assay, from the lowest: compounds 1, 2, 4 and 3 (each within the scatter of the next).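

In this assay, among the compounds shown here, the exchange on the aromatic carbon next to the ring nitrogen gives a 1.2-fold lower number from compound 3 to compound 4 (0.08 log units; within the scatter), which is the first reading taken at this position rather than on the aromatic nitrogen that carries the aryl group in compound 1 and compound 2. A 4-chlorophenyl group and a 2-fluorophenyl group cannot be separated here, so across these two groups the choice of halogenated phenyl does not register in this read-out. No measurement bears on why this step stays within the scatter.

This single step alters both the halogen and its place on the phenyl ring, so the contribution of each remains unresolved, and every aryl group shown is either a plain phenyl or a halogenated phenyl. As far as these compounds go, it also remains open whether an aminomethyl group or a carboxylic acid on that phenyl ring, or a longer alkyl chain in place of the ring, would take the number at this position beyond the scatter.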